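The source may report more compounds than this note shows. Statements on the series, on what has been measured and on what is new or still open speak of the compounds shown alone.

Measured in an ADME assay on HepG2 cells (Homo sapiens) for cytotoxicity, read by MTT assay, with a stated time of 72 h; a higher number here means that more compound is tolerated, a lower number that less compound is tolerated:

compound 1, `CC1(c2ccc(Br)cc2)CC(S(=O)(=O)c2ccc(F)cc2)=C(c2ccc(/C(N)=N\O)cc2)O1`: 19200 nM
compound 2, `CC1(c2ccc(-c3ccccc3C#N)cc2)CC(S(=O)(=O)c2ccc(F)cc2)=C(c2ccc(/C(N)=N\O)cc2)O1`: 58300 nM
compound 3, `CC1(c2ccc(Cl)cc2)CC(S(=O)(=O)c2ccc(F)cc2)=C(c2ccc(/C(N)=N\O)cc2)O1`: 61400 nM

Compound 3 stands highest of the three numbers, though only narrowly: the step of a 1.1-fold higher number from compound 2 to compound 3 (0.02 log units; within the scatter) lies within the scatter, so compound 2 and compound 3 cannot be ordered, while the step of a 3.2-fold higher number from compound 1 to compound 3 (0.50 log units; beyond the scatter) is beyond it and sets compound 1 apart as the lowest.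

The next compound, compound 4, `COc1cc(-c2ccc(C3(C)CC(S(=O)(=O)c4ccc(F)cc4)=C(c4ccc(/C(N)=N\O)cc4)O3)cc2)cc(OC)c1OC`, arises from compound 3 through (3,4,5-trimethoxyphenyl in place of chloro on an aromatic carbon).

Going by the values given here, two measured steps bear on this. The step of a 3.0-fold higher number from compound 1 to compound 2 (0.48 log units; beyond the scatter) shows an aromatic group entering in place of a halogen, with a modest rise. The step of a 1.1-fold higher number from compound 2 to compound 3 (0.02 log units; within the scatter) shows chloro and an aromatic group giving numbers within the scatter of each other. Taken together, exchanging chloro for an aromatic group is expected to move this assay little, if at all, so the step of a 1.1-fold lower number from compound 3 to compound 4 (0.05 log units; within the scatter) is estimated to stay within the scatter. For compound 4 the expected value in this assay is 55000 nM, with a range from 25000 nM to 120000 nM.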

Compound 4, half-maximal cytotoxic concentration: > 50000 nM
Compound 4 was reported as a limit; the forecaster's own chance of this, stated with the estimate: 20%; the middle value does not contradict the limit.
By their numbers in this assay, from the lowest: compound 1; then compounds 2 and 3 (each within the scatter of the next).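

With 3,4,5-trimethoxyphenyl on the aromatic carbon where compounds 1, 2 and 3 vary, compound 4 is reported only as a limit, > 50000 nM in this assay, and not as a number. Even so, the change from bromo can be read, as an at least 2.6-fold higher number from compound 1 to compound 4 (0.41 log units; beyond the scatter) shows, so a larger aromatic group bearing three methoxy groups, like the 2-cyanophenyl of compound 2, does not bring the number down to that of compound 1. The steps to compound 4 from compound 2 and from compound 3 cannot be read because of the limit: the limit of > 50000 nM in this assay, at which 1 of the 4 values shown sits.

On these data alone, how far compound 4 lies past its limit remains open, and with it any order among compounds 2, 3 and 4. Also open, as far as these compounds go, is how a non-aromatic group at this position, such as an amine, a carboxylic acid or a longer alkyl chain, would read in this assay.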